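A few compounds are considered here, and "the series" means these few. Any claim that something is new, unique, unknown or untested is made for them only; others in the source may bear on it.

Measured so far in an assay on Sf9 cells for inhibition of Leucine-rich repeat serine/threonine-protein kinase 2 (Homo sapiens), read by TR-FRET, with stated times of 30 min and 2 h; a lower number here means a stronger inhibitor, a higher number a weaker inhibitor:
compound 1 `O=C(Nc1ccnnc1)c1cc(N2CCNCC2)ccc1OCc1ccccc1` gives 15.9 nM;
compound 2 `O=C(Nc1ccnnc1)c1cc(N2CCC(F)CC2)ccc1OCc1ccccc1` gives 39.8 nM;
compound 3 `CN1CCC(c2ccc(OCc3ccccc3)c(C(=O)Nc3ccnnc3)c2)CC1` gives 20 nM.

Compound 3 stands with the second highest of these three numbers. Its nearest neighbour is compound 1, and the step of a 1.3-fold higher number from compound 1 to compound 3 (0.10 log units; within the scatter) lies within the scatter; its furthest neighbour is compound 2, and the step of a 2.0-fold lower number from compound 2 to compound 3 (0.30 log units; within the scatter) also lies within the scatter, so compound 3 cannot be ranked against either of them on these numbers.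

Compound 4 `O=C(Nc1ccnnc1)c1cc(N2CCC(O)CC2)ccc1OCc1ccccc1` differs from compound 3 in one place:
4-hydroxypiperidin-1-yl in place of 1-methylpiperidin-4-yl on an aromatic carbon

Among the measured compounds shown here, two measured steps bear on this. The step of a 2.0-fold lower number from compound 2 to compound 3 (0.30 log units; within the scatter) joins compound 3 to compound 2, whose 4-fluoropiperidin-1-yl group is the closest relative of the group entering in compound 4. The step of a 2.5-fold higher number from compound 1 to compound 2 (0.40 log units; beyond the scatter) shows that swapping the piperazin-1-yl of compound 1 for that same 4-fluoropiperidin-1-yl gave a modest rise, beyond the scatter. Taken together, the three groups tried here span only a narrow range in this assay, so for compound 4 a small rise toward the value of compound 2 is expected, a 1.5-fold higher number from compound 3 to compound 4 (0.18 log units; within the scatter), probably still within the scatter. The estimate for compound 4 in this assay is 30 nM, with a likely range from 12 nM to 75 nM.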

Compound 4, half-maximal inhibitory concentration: 39.8 nM
Compound 4: the middle estimate sits 1.3-fold (0.12 log units) below what was measured, and the stated range covers the measured number.
By their numbers in this assay, from the lowest: compounds 1, 3, 2 and 4 (each within the scatter of the next, the first and the last beyond it).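

In this assay, exchanging the ring substituent itself, with hydroxy in place of fluoro on a saturated ring carbon, gives no change at the digits printed from compound 2 to compound 4 (within the scatter), so the two groups cannot be told apart at this position. Compound 4 also stands apart from the piperazin-1-yl compound, with a 2.5-fold higher number from compound 1 to compound 4 (0.40 log units; beyond the scatter), which means that two 4-substituted piperidin-1-yl groups now share this modest gap beyond the scatter, while compound 3 goes against any wider piperidine pattern: it stays within the scatter of compound 1, and a 2.0-fold higher number from compound 3 to compound 4 (0.30 log units; within the scatter) also stays within the scatter, even though the hydroxy group brings a hydrogen-bond donor that 1-methylpiperidin-4-yl does not have. No measurement shown here offers an explanation for these small differences.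

Across these four compounds, the group at this position has moved the number only modestly, so it remains open whether a morpholin-4-yl ring, a 4-aminopiperidin-1-yl group or a piperidine bearing a carboxylic acid would shift it further. The shared core has stayed the same throughout, which also leaves open whether these small gaps would hold with a different group in place of the benzyloxy group.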